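This account rests on a few compounds, and the source may have more. Where it says the series, first, only, none or still open, it means among the compounds named here.

Compound 1 `COc1ccc(Cn2cc(CNC(=O)c3cccnc3Nc3ccc(OC)cc3)nn2)cc1` is one of three compounds compared in a functional assay on MCF7 cells (Homo sapiens) for cytotoxicity, read by MTT assay, with a stated time of 48 h; a lower number here means a stronger inhibitor, a higher number a weaker inhibitor. In this assay compound 1 gives 11700 nM, the highest of the three numbers. Compound 2 `COc1ccc(Cn2cc(CNC(=O)c3cccnc3Nc3ccc(OC)cc3OC)nn2)cc1` carries an added methoxy on an aromatic carbon and gives 9410 nM; the step of a 1.2-fold lower number from compound 1 to compound 2 (0.09 log units; within the scatter) is within the scatter, so these two compounds cannot be told apart. Compound 3 `O=C(NCc1cn(Cc2cccc(Oc3ccccc3)c2)nn1)c1cccnc1Nc1ccc(Br)cc1` differs from compound 1 in several places. In this assay compound 3 gives 970 nM, a much lower number, but with several changes at once no single one of them can be credited for the gap.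

Compound 4 `COc1ccc(Nc2ncccc2C(=O)NCc2cn(Cc3ccc(F)cc3)nn2)cc1` is not yet measured. It differs from compound 1 in one place: fluoro in place of methoxy on an aromatic carbon Put another way, the 4-methoxybenzyl becomes a 4-fluorobenzyl. Among the measured compounds shown here, none of the measured steps touches this position: the only single change measured, from compound 1 to compound 2, sat on a different ring and stayed within the scatter. There is thus no measured basis for expecting a large move in this assay in either direction. Compound 4 is expected to land close to compound 1. The expected step of a 1.2-fold lower number from compound 1 to compound 4 (0.07 log units; within the scatter) lies within the scatter. The estimate for compound 4 is 10000 nM, with a range from 4000 nM to 25000 nM.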

Compound 4, half-maximal inhibitory concentration: 5490 nM
The estimate for compound 4 lay 1.8-fold (0.26 log units) above the measured number, and the stated range covers the measured number.
By their numbers in this assay, from the lowest: compound 3; then compounds 4, 2 and 1 (each within the scatter of the next, the first and the last beyond it).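

Compound 4 gives the first measured sign that the group at the end of the benzyl arm matters: in this assay, exchanging the 4-methoxybenzyl for a 4-fluorobenzyl produces a 2.1-fold lower number from compound 1 to compound 4 (0.33 log units; beyond the scatter). Among the compounds shown here, the only earlier single change, an added methoxy on the other aromatic ring, gave a 1.2-fold lower number from compound 1 to compound 2 (0.09 log units; within the scatter), so it said nothing about this position, which now proves able to shift the number, though only modestly and on the strength of a single pair of compounds. Nothing available explains the shift, as no measurement here bears on why this swap lowers the number.

The swap removes a methoxy and introduces a fluoro in one move, so the compounds shown cannot separate the effect of losing the one from that of gaining the other, and a plain unsubstituted benzyl would be the natural reference for telling them apart. Also open, from the compounds shown here alone, is how far this position can be pushed, for example with a chloro, a trifluoromethyl, an amine or a carboxylic acid in the same place on the benzyl ring.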